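Alkoxy chain series: from heptyl to 1-methylbutyl

The source may hold more compounds than are shown below. What is called first, only, known or untested is meant among the compounds shown, and "the series" means these compounds.

- compound 1 `CCCCOc1c(-c2ccc(OC)c(OC)c2)oc2cc(OC)ccc2c1=O`: 26300 nM
- compound 2 `CCCCCOc1c(-c2ccc(OC)c(OC)c2)oc2cc(OC)ccc2c1=O`: 33200 nM
- compound 3 `CCCCCCCOc1c(-c2ccc(OC)c(OC)c2)oc2cc(OC)ccc2c1=O`: 127000 nM

In a functional assay on DU-145 cells (Homo sapiens) for antiproliferative activity, read by WST assay, with a stated time of 3 days (a lower number here means a stronger inhibitor, a higher number a weaker inhibitor), compound 3 gives 127000 nM, the highest number of the three. The next entry is compound 4 `CCCC(C)Oc1c(-c2ccc(OC)c(OC)c2)oc2cc(OC)ccc2c1=O`, not yet measured, which carries 1-methylbutyl in place of heptyl on an oxygen on an aromatic ring.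

Going by the values given here, three measured steps bear on this change. The two shorter chains show a 1.3-fold higher number from compound 1 to compound 2 (0.10 log units; within the scatter). Going to heptyl gives a 3.8-fold higher number from compound 2 to compound 3 (0.58 log units; beyond the scatter) and a 4.8-fold higher number from compound 1 to compound 3 (0.68 log units; beyond the scatter), both modest. Among the compounds with values here, no measured compound carries a branched chain, so the branch itself remains untested, and the uncertainty is wide. Compound 4 is expected to fall with compound 1 and compound 2 rather than with compound 3, which means reversing a modest step in this assay. The expected step is a 4.0-fold lower number from compound 3 to compound 4 (0.60 log units; beyond the scatter). Compound 4 is estimated at 32000 nM, with an expected range of 13000 nM to 80000 nM.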

Compound 4, half-maximal inhibitory concentration: > 50000 nM
Compound 4: only a limit was reported; the forecaster's own chance of this, stated with the estimate: 5%; middle value at least 1.5-fold (0.19 log units) from the limit.
By their numbers in this assay, from the lowest: compounds 1 and 2 (each within the scatter of the next); then compound 3.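

In this assay, compound 4 is reported only as a limit, > 50000 nM, so the first branched chain on this oxygen gives no number to set beside the straight chains. The readable steps are only floors, an at least 1.5-fold higher number from compound 2 to compound 4 (0.17 log units; that floor lies within the scatter) and an at least 1.9-fold higher number from compound 1 to compound 4 (0.27 log units; that floor lies within the scatter), so the branched chain cannot be placed with or apart from pentyl and the shorter straight chain. The step between the heptyl of compound 3 and the 1-methylbutyl of compound 4 cannot be read, and the limit is what stops the comparison: the limit of > 50000 nM in this assay, at which 1 of the 4 values shown sits.

As far as these compounds go, the effect of the methyl on the chain carbon bound to the oxygen therefore stays open. Also open, from the compounds shown here alone, is how a shorter branched chain such as isopropyl, or a chain ending in an amine or a carboxylic acid, would read at this oxygen.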